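A few compounds are considered here, and "the series" means these few. Any claim that something is new, unique, unknown or untested is made for them only; others in the source may bear on it.

Compound 1 `COc1ccccc1S(=O)(=O)/C=C/c1ccccn1` was tested in an assay on U2OS cells for activation of nuclear factor erythroid 2-related factor 2 (Homo sapiens), read by chemiluminescence, with a stated time of 6 h (on this read-out higher numbers stand for an effect only at larger amounts of compound and lower numbers for an effect already at smaller amounts), where compound 1 gives 9070 nM. Of the two numbers recorded so far it is the highest; its nearest neighbour is compound 2 `COc1ccccc1S(=O)(=O)/C=C/c1ccc(Cl)cn1`, which in this assay gives 6310 nM, and the step from compound 1 to compound 2 in this assay is a 1.4-fold lower number from compound 1 to compound 2 (0.16 log units; within the scatter), so the two lie within the scatter of each other.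

Compound 3 `COc1ccccc1S(=O)(=O)/C=C/c1cccnc1` has not yet been measured. It differs from compound 1 in one place: pyridin-3-yl in place of pyridin-2-yl on a double-bonded chain carbon bound to a double-bonded chain carbon. Within the data shown here, the one measured step, from compound 1 to compound 2, concerns a chloro in place of hydrogen on an aromatic carbon and so does not bear on a change in the point through which the pyridine ring is joined to the chain; no measured pair speaks to this change. In the absence of any relevant step, no move beyond the scatter in this assay is expected, and the step from compound 1 to compound 3 is estimated at a 1.0-fold lower number from compound 1 to compound 3 (0.00 log units; within the scatter). Compound 3 is therefore expected to give about 9000 nM in this assay, with a range from 3000 nM to 27000 nM.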

Compound 3, half-maximal effective concentration: > 10000 nM
Compound 3: a limit, no number (the forecaster's own chance of this, stated with the estimate: 15%); middle value at least 1.1-fold (0.04 log units) away from the limit.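

Compound 3 is the first compound shown in which the pyridine ring changes its point of attachment instead of taking on a new substituent, and the result concerns a place the chloro step could not address: a double-bonded chain carbon bound to a double-bonded chain carbon. With pyridin-3-yl at this place, this assay gives no number for compound 3, and its reading is a limit of the assay: (the limit of > 10000 nM in this assay, at which 1 of the 3 values shown sits). The step for pyridin-3-yl in place of pyridin-2-yl is therefore only a floor (an at least 1.1-fold higher number from compound 1 to compound 3 (0.04 log units; that floor lies within the scatter)), so the change is not shown to lie beyond the scatter, although a larger move remains possible.

From the compounds shown here alone, how far compound 3 really lies from compound 1 stays unknown, and so does whether a chloro in place of hydrogen on an aromatic carbon would act on the pyridin-3-yl ring as it does on the pyridin-2-yl ring. Also open, going by these compounds, is what a phenyl ring, or a pyridine ring carrying an amine, would do at this same place on the chain.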